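A methoxy for methyl swap in a sulfonamide series

The source may hold more compounds than are shown below. What is called first, only, known or untested is meant among the compounds shown, and "the series" means these compounds.

Three compounds sharing one core have been measured in a functional assay on DU-145 cells (Homo sapiens) for antiproliferative activity, read by MTT assay, with a stated time of 72 h; a higher number here means a weaker inhibitor, a lower number a stronger inhibitor:

compound 1 `CN(c1ccccc1Cl)S(=O)(=O)C1CC2OC1C(c1ccc(NC(=O)CCCCCCC(=O)O)cc1)=C2c1ccc(O)cc1` 73500 nM
compound 2 `CN(c1ccc(Cl)cc1)S(=O)(=O)C1CC2OC1C(c1ccc(NC(=O)CCCCCCC(=O)O)cc1)=C2c1ccc(O)cc1` 72100 nM
compound 3 `CCN(c1cccc(C)c1)S(=O)(=O)C1CC2OC1C(c1ccc(NC(=O)CCCCCCC(=O)O)cc1)=C2c1ccc(O)cc1` 65600 nM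

Compound 3 stands level with the other two, since no gap among the three exceeds the scatter. Exchanging the 2-chlorophenyl on the sulfonamide nitrogen for 4-chlorophenyl gave a 1.0-fold lower number from compound 1 to compound 2 (0.01 log units; within the scatter). Introducing the ethyl(3-methylphenyl)amino group gave a 1.1-fold lower number from compound 1 to compound 3 (0.05 log units; within the scatter), and the comparison with the other chlorinated partner gave a 1.1-fold lower number from compound 2 to compound 3 (0.04 log units; within the scatter).

The next step leads to compound 4 `CCN(c1cccc(OC)c1)S(=O)(=O)C1CC2OC1C(c1ccc(NC(=O)CCCCCCC(=O)O)cc1)=C2c1ccc(O)cc1`, and the change is methoxy in place of methyl on an aromatic carbon. It places methoxy in place of methyl on an aromatic carbon, meta to a large group, turning 3-methylphenyl into 3-methoxyphenyl. For the measured compounds named here, no measured step makes this exact exchange, so the evidence is indirect. The three steps above all altered the same aromatic group on the sulfonamide nitrogen, and each stayed within the scatter. A shift beyond the scatter in this assay is therefore not expected, and no direction can be favoured. The estimated change is a 1.0-fold lower number from compound 3 to compound 4 (0.00 log units; within the scatter). Compound 4 is expected at 65000 nM, with an estimated range from 38000 nM to 100000 nM.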

Compound 4, half-maximal inhibitory concentration: 71100 nM
Compound 4: middle estimate off by 1.1-fold (0.04 log units), on the low side; the measured number falls inside the stated range.
By their numbers in this assay, from the lowest: compounds 3, 4, 2 and 1 (each within the scatter of the next).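

In this assay, for the compounds shown here, this is the first direct reading at this aromatic carbon, meta to a large group, and methoxy in place of methyl gives a 1.1-fold higher number from compound 3 to compound 4 (0.03 log units; within the scatter), so bringing in the hydrogen-bond acceptor of methoxy leaves the number within the scatter. Compound 4 also stands level with the two chlorinated partners, with a 1.0-fold lower number from compound 2 to compound 4 (0.01 log units; within the scatter) and a 1.0-fold lower number from compound 1 to compound 4 (0.01 log units; within the scatter), so all four compounds lie within the scatter of one another, whether the aromatic group on the sulfonamide nitrogen bears chlorine, methyl or methoxy. No measured evidence is available to explain why the methyl and methoxy compounds stand level.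

Still open, going by these compounds, is whether a different group on this aromatic carbon, such as an amine or a carboxylic acid, would carry the number beyond the scatter, as the three substituents compared here do not show how wide a range of groups this position tolerates. Also open, on these data alone, is whether changes away from this aromatic group, such as a shorter or longer chain on the amide carbonyl, would shift the number.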